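Extending the methoxy group of a low-inhibition amide

The source may report more compounds than this note shows. Statements on the series, on what has been measured and on what is new or still open speak of the compounds shown alone.

Measured compounds:
compound 1, `C=CS(=O)(=O)NC/C=C/c1cc(OC)cc(O)c1C(=O)OC(C)C`, in an assay on isolated protein for inhibition of MAP kinase-interacting serine/threonine-protein kinase 2 (Homo sapiens), tested at 10 uM (a lower number here means less inhibition, a higher number more inhibition at the concentration tested (going by the name of the read-out)), compound 1 gives 13.9%
compound 2, `CCN(CC)C/C=C/C(=O)NC/C=C/c1cc(OC)cc(O)c1C(=O)OC(C)C`, in this assay compound 2 gives 5.2%

Both measured compounds share a core and differ in the group on the sulfonamide or amide side. Compound 2, with its diethylaminobutenamide, gives a number that stands within the usual scatter of the number for compound 1, so the two cannot be told apart on these data; both sit at the low end of the read-out. Among the compounds with values here, no step between measured compounds is separated from the scatter here.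

Compound 3, `CCN(CC)C/C=C/C(=O)NC/C=C/c1cc(OCCc2ccc(F)cc2)cc(O)c1C(=O)OC(C)C`, keeps the whole of compound 2 and differs only at the methoxy group: 4-fluorobenzyl in place of hydrogen on a saturated chain carbon bound to an oxygen on an aromatic ring. Within the data shown here, nothing measured shows how this change acts; no pair in the data tests it. From compound 2 to compound 3 the step expected in this assay is a number 4.8 percentage points higher from compound 2 to compound 3 (within the scatter), which is within the scatter and carries no direction that the data can support. Compound 3 is therefore estimated at 10%, with a range from 0% to 35%.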

Compound 3, a percentage reported as inhibition, at one concentration (the size of the read-out at that concentration, not a potency): 0.8%
For compound 3 the middle estimate is 9.2 percentage points above the measured one; the measured number falls inside the stated range.
By their numbers in this assay, from the lowest: compounds 3, 2 and 1 (each within the scatter of the next, the first and the last beyond it).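

Within the data shown here, replacing the methoxy group of compound 2 with 2-(4-fluorophenyl)ethoxy is the first change here that can be read as a single step, and in this assay it comes out as a number 4.4 percentage points lower from compound 2 to compound 3 (within the scatter) for this position. The position therefore carries 4-fluorobenzyl, with its 8 heavy atoms and one six-membered aromatic ring, on the saturated chain carbon bound to an oxygen on an aromatic ring, and the two compounds still cannot be told apart by this read-out. Nothing in the data shown accounts for this result.

Still open, as far as these compounds go, is whether a group at this position can move the number clear of the scatter: a carboxylic acid or an amine at the end of the chain, a longer chain, or a plain phenyl without the fluorine could each be set against 4-fluorobenzyl. Also open is whether the same 2-(4-fluorophenyl)ethoxy group on the sulfonamide side of the series would stand apart from compound 1 at 13.9% in this assay, since that pair does not appear among the compounds shown.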